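The compounds below may be only part of what the source reports. "The series", "measured", "known", "first", "only" and "open" are said of these compounds alone.

Measured in a functional assay on A-375 cells (Homo sapiens) for antiproliferative activity; on this read-out higher numbers stand for weaker inhibition and lower numbers for stronger inhibition:
- compound 1 `O=C(Nc1ccc(-c2cscn2)cc1)C1CCCN(C(=O)c2ccc(F)c(F)c2)C1`: > 20000 nM, a limit of the assay
- compound 2 `O=C(Nc1ccc(-c2cscn2)cc1)C1CCCN(Cc2cccc(F)c2)C1`: 2450 nM
- compound 3 `O=C(Nc1ccc(-c2cscn2)cc1)C1CCCN(Cc2ccc(F)cc2)C1`: 2250 nM

Compound 3 stands level with compound 2, the step being a 1.1-fold lower number from compound 2 to compound 3 (0.04 log units; within the scatter). Compound 4 `O=C(Nc1ccc(-c2cscn2)cc1)C1CCCN(Cc2cccc(F)c2F)C1` is not yet measured. It carries 2,3-difluorophenyl in place of 4-fluorophenyl on a saturated chain carbon bound to an amine nitrogen in a ring.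

Among the compounds with values here, the closest precedent is the exchange of 3-fluorophenyl for 4-fluorophenyl at this place, a 1.1-fold lower number from compound 2 to compound 3 (0.04 log units; within the scatter). The two larger steps, an at least 8.1-fold lower number from compound 1 to compound 2 (0.91 log units; beyond the scatter) and an at least 8.8-fold lower number from compound 1 to compound 3 (0.94 log units; beyond the scatter), replace the (3,4-difluorophenyl)carbonyl group with a fluorobenzyl group. Within the data shown here, they show only that the benzyl compounds give numbers in this assay, and they say little about a second fluorine on the benzyl ring. Among the measured compounds shown here, no measured compound carries a difluorobenzyl group, so the expectation rests on one small step.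

No change beyond the scatter is therefore expected, and the estimated step is a 1.0-fold higher number from compound 3 to compound 4 (0.01 log units; within the scatter). Compound 4 is estimated at 2300 nM, with an expected range of 900 nM to 6000 nM.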

Compound 4, half-maximal inhibitory concentration: 1480 nM
Beside the measured number, compound 4's estimate is 1.6-fold (0.19 log units) above it; the range from low to high includes it.
By their numbers in this assay, from the lowest: compounds 4, 3 and 2 (each within the scatter of the next). At a limit, above all of these: compound 1.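

A second fluorine on the benzyl ring, as in 2,3-difluorobenzyl, leaves the read-out in this assay within the scatter of both monofluorinated compounds: a 1.5-fold lower number from compound 3 to compound 4 (0.18 log units; within the scatter), and a 1.7-fold lower number from compound 2 to compound 4 (0.22 log units; within the scatter). The difference between the carbonyl-linked and benzyl-linked compounds also holds with this new group: an at least 13-fold lower number from compound 1 to compound 4 (1.13 log units; beyond the scatter). Compound 1 remains a limit rather than a number, so this step has no fixed size: the limit of > 20000 nM in this assay, at which 1 of the 4 values shown sits.

The compounds shown leave open whether the flat response at this position extends beyond fluoro to other substituents on the benzyl ring, such as methoxy, nitrile or trifluoromethyl. Also open, going by these compounds, is whether a pyridine ring in place of the fluorinated benzene ring, or a change elsewhere on the shared core, would move the number beyond the scatter.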